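The compounds below may be only part of what the source reports. "The series", "measured", "known", "first", "only" and "open" are said of these compounds alone.

Measured so far in an assay on cells for antagonist activity at transient receptor potential cation channel subfamily V member 1 (Homo sapiens), read by FLIPR and calcium flux, with a stated time of 6 min; a lower number here means a stronger inhibitor, a higher number a weaker inhibitor:
- compound 1 `CC(C(=O)NCc1ccc(C(C)(C)C)nc1SCCCN(C)C)c1ccc(NS(C)(=O)=O)c(F)c1`: 51.8 nM
- compound 2 `CCCCCc1nc(C(C)(C)C)ccc1CNC(=O)C(C)c1ccc(NS(C)(=O)=O)c(F)c1`: 1.9 nM
- compound 3 `CC(C(=O)NCc1ccc(C(C)(C)C)cc1N1CCCC1)c1ccc(NS(C)(=O)=O)c(F)c1`: 8.1 nM

Compound 3 holds the second highest of the three numbers in this assay. Its nearest neighbour is compound 2, whose number is lower by more than the scatter; its furthest is compound 1, whose number is higher, again beyond the scatter.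

Compound 4 `CCCCCCOc1cc(C(C)(C)C)ccc1CNC(=O)C(C)c1ccc(NS(C)(=O)=O)c(F)c1` differs from compound 3 in one place: hexyloxy in place of pyrrolidin-1-yl on an aromatic carbon. The group that leaves has a five-membered non-aromatic ring with one hetero atom; the group that enters is a chain of seven heavy atoms with no ring, placed ortho to a large group and meta to a tert-butyl group.

Going by the values given here, one measured step bears on this change: a 27-fold lower number from compound 1 to compound 2 (1.44 log units; beyond the scatter), where a plain chain on an aromatic carbon replaced a heteroatom-linked substituent and the number dropped sharply. Here a chain likewise replaces a nitrogen-linked ring on the aromatic carbon, so a lowering is expected, though smaller, since compound 3 already sits well below compound 1. Compound 4 is therefore expected at 4 nM, range 1.5 nM to 12 nM, a step of a 2.0-fold lower number from compound 3 to compound 4 (0.31 log units; beyond the scatter).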

Compound 4, inhibition constant: 0.5 nM
For compound 4 the middle estimate is 8.0-fold (0.90 log units) above the measured one, and the stated range ends above it.
By their numbers in this assay, from the lowest: compound 4; then compound 2; then compound 3; then compound 1.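

In this assay, a 16-fold lower number from compound 3 to compound 4 (1.21 log units; beyond the scatter), so this aromatic carbon, ortho to a large group and meta to a tert-butyl group, accepts an open chain in place of a ring, with a large lowering of the number. Read alone, a 27-fold lower number from compound 1 to compound 2 (1.44 log units; beyond the scatter) could suggest that only a chain joined directly through carbon goes with a large lowering, but the hexyloxy chain is joined through oxygen and shows one too, on the core of compound 3. Nothing measured here accounts for the size of this step.

On these data alone, whether the lowering follows the oxygen link, the chain length or the loss of the ring remains open, and a plain hexyl or a butoxy group at this carbon would separate these readings. As far as these compounds go, how a terminal amine or carboxylic acid on the hexyloxy chain would read in this assay is also open.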